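This account rests on a few compounds, and the source may have more. Where it says the series, first, only, none or still open, it means among the compounds named here.

- Compound 1 `CC(C)CN(c1ccc(C#N)cc1)S(=O)(=O)c1ccc2c(c1)C(=O)CC(C1CCOCC1)O2`: 3.16
- Compound 2 `CCc1ccc(N(CC(C)C)S(=O)(=O)c2ccc3c(c2)C(=O)CC(C2(C)CCOCC2)O3)cc1`: 4.71
- Compound 3 `CCc1ccc2c(c1)CC(C)CN2S(=O)(=O)c1ccc2c(c1)C(=O)CC(C1CCOCC1)O2`: 3.77

These numbers come from a physicochemical assay for lipophilicity, at pH 7.4; on this read-out lower numbers stand for lower lipophilicity and higher numbers for higher lipophilicity. Compound 1 gives 3.16, the lowest of the three. Compound 3, at 3.77, and compound 2, at 4.71, both lie above it, beyond the scatter.

Compound 4 `CC(C)CN(Cc1ccccc1C(F)(F)F)S(=O)(=O)c1ccc2c(c1)C(=O)CC(C1CCOCC1)O2` has not yet been measured. It differs from compound 1 in one place: 2-(trifluoromethyl)benzyl in place of 4-cyanophenyl on a sulfonamide nitrogen. In words, 2-(trifluoromethyl)benzyl stands in place of 4-cyanophenyl on a sulfonamide nitrogen.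

Among the compounds with values here, no two measured compounds differ in just one place, so nothing here calibrates this swap directly. Within the data shown here, the only guide is a loose one: compound 1, at 3.16, is the only measured compound with 4-cyanophenyl, and compound 2, at 4.71, and compound 3, at 3.77, lack that group and read higher. A rise in this assay is therefore expected, beyond the scatter. The expected size of the move is a number 0.94 log units higher from compound 1 to compound 4 (beyond the scatter). Compound 4 is estimated at 4.1, with an expected range of 3.6 to 4.7.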

Compound 4, distribution coefficient: 4.32
Compound 4: the middle estimate sits 0.22 log units below what was measured, and the stated range covers the measured number.
By their numbers in this assay, from the lowest: compound 1; then compound 3; then compound 4; then compound 2.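

Placed on the sulfonamide nitrogen, 2-(trifluoromethyl)benzyl in place of 4-cyanophenyl gives a number 1.16 log units higher from compound 1 to compound 4 (beyond the scatter) in this assay. Within the data shown here, the earlier compounds differed from one another in more than one place, so this is the first direct sign that this position alone can shift the read-out so strongly. The swap still changes several things together, including heavy atoms, fluorine and the nitrile with its hydrogen-bond acceptor, and nothing measured here shows which of these differences accounts for the step.

From the compounds shown here alone, it remains open how much of the step belongs to the trifluoromethyl group and how much to the benzyl framework, which a plain benzyl group at this position could help separate. Going by these compounds, the response of this position to an amine or a carboxylic acid also remains open.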